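Removing a Methyl from the Aromatic Oxygen of Compound 2

This account rests on a few compounds, and the source may have more. Where it says the series, first, only, none or still open, it means among the compounds named here.

Compound 1 `O=C(Nc1cccc(-n2cc(-c3ccncc3)c(-c3ccc(Cl)c(O)c3)n2)c1)Nc1cccc(C(F)(F)F)c1` — 6910 nM
Compound 2 `COc1cc(-c2nn(-c3cccc(NC(=O)Nc4ccc(Cl)c(Cl)c4)c3)cc2-c2ccncc2)ccc1Cl` — 1860 nM

Of the compounds shown here, two have been tested in a functional assay on UACC-62 cells (Homo sapiens) for inhibition, read by sulforhodamine B assay, with a stated time of 48 h; on this read-out higher numbers stand for weaker inhibition of growth and lower numbers for stronger inhibition of growth. Compound 1 gives 6910 nM, and compound 2 gives 1860 nM. Compound 2 therefore has the lower of the two numbers, and the gap between it and compound 1 lies beyond the usual scatter. The two compounds differ in more than one place, so this gap cannot be assigned to any single change.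

Compound 3 `O=C(Nc1cccc(-n2cc(-c3ccncc3)c(-c3ccc(Cl)c(O)c3)n2)c1)Nc1ccc(Cl)c(Cl)c1` has not yet been measured. It differs from compound 2 in one place: hydrogen in place of methyl on an oxygen on an aromatic ring. Among the compounds with values here, since no measured pair shows this change on its own, there is no direct guide to its size. The step from compound 2 to compound 3 is expected to be small, most likely no change beyond the scatter, as a 1.3-fold higher number from compound 2 to compound 3 (0.13 log units; within the scatter). Compound 3 is expected to give 2500 nM, with a range from 900 nM to 7000 nM.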

Compound 3, concentration for total growth inhibition: 5210 nM
The estimate for compound 3 lay 2.1-fold (0.32 log units) below the measured number, and the stated range covers the measured number.
By their numbers in this assay, from the lowest: compound 2; then compounds 3 and 1 (each within the scatter of the next).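

Swapping methoxy for hydroxy on the 4-chloro-3-methoxyphenyl group is the first change here that can be read on its own, and in this assay it brings a 2.8-fold higher number from compound 2 to compound 3 (0.45 log units; beyond the scatter) so the methyl on this oxygen makes a modest but real difference to this read-out. The second single change, 3,4-dichlorophenyl in place of 3-(trifluoromethyl)phenyl on an amide-type nitrogen, brings a 1.3-fold lower number from compound 1 to compound 3 (0.12 log units; within the scatter) so with the hydroxy present these two groups cannot be told apart here. Nothing measured on these compounds explains the effect of the methyl.

On these data alone, it remains open whether the same methoxy-to-hydroxy change would have a similar size with 3-(trifluoromethyl)phenyl on that nitrogen. Also open, as far as these compounds go, is how an ethyl, or a longer chain ending in an amine, on this oxygen would compare with methyl and hydrogen.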